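The source may hold more compounds than are shown below. What is called first, only, known or untested is meant among the compounds shown, and "the series" means these compounds.

Compound 2 `C[C@@]1(c2cc(NC(=O)c3cnc(C(F)F)cn3)ccc2F)C=C(CF)OC(N)=N1` stands highest of the two numbers in an ADME assay on microsomes from liver (Homo sapiens) for metabolic stability, read by LC-MS, using NADPH, with a stated time of 30 min, tested at 0.1 uM (on this read-out higher numbers stand for a more stable compound and lower numbers for a less stable compound), where compound 2 gives 84%; the nearest, compound 1 `C[C@@]1(c2cc(NC(=O)c3ncc(C#N)cc3Cl)ccc2F)C=C(CF)OC(N)=N1`, gives 57%. For the measured compounds named here, the single measured step, a number 27 percentage points higher from compound 1 to compound 2 (beyond the scatter), concerns the same group on the carbonyl carbon and so bears directly on the next change. Compound 3 `COc1cc(C#N)cnc1C(=O)Nc1ccc(F)c([C@]2(C)C=C(CF)OC(N)=N2)c1` differs from compound 2 by 5-cyano-3-methoxypyridin-2-yl in place of 5-(difluoromethyl)pyrazin-2-yl on a carbonyl carbon. Because compound 1, carrying 3-chloro-5-cyanopyridin-2-yl, gave 57%, a return toward that level is expected. The expected step is a number 29 percentage points lower from compound 2 to compound 3 (beyond the scatter). Compound 3 is therefore estimated at 55%, between 35% and 75%.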

Compound 3, percent of the compound remaining: 85%
Compound 3: middle estimate off by 30 percentage points, on the low side; the whole stated range lies below it.
By their numbers in this assay, from the lowest: compound 1; then compounds 2 and 3 (each within the scatter of the next).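

Methoxy in place of chloro on an aromatic carbon gives a number 28 percentage points higher from compound 1 to compound 3 (beyond the scatter) in this assay and this shows that a group carrying the 5-cyano need not stay at the level of compound 1. The other step, a number 1 percentage points higher from compound 2 to compound 3 (within the scatter), shows that 5-cyano-3-methoxypyridin-2-yl and 5-(difluoromethyl)pyrazin-2-yl cannot be told apart on this read-out when placed on the carbonyl carbon. Nothing given here explains either step.

From the compounds shown here alone, whether ethoxy or a dimethylamino group on that aromatic carbon would give a similar number remains open. So does what happens to the number when the nitrile is replaced by an amide.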